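Hydroxytyrosol-like ester of a glucoside core on HL-60 cells

The compounds below may be only part of what the source reports. "The series", "measured", "known", "first", "only" and "open" are said of these compounds alone.

Measured compounds:
Compound 1 `C/C=C1/[C@H](O[C@@H]2O[C@H](COC(C)=O)[C@@H](OC(C)=O)[C@H](OC(C)=O)[C@H]2OC(C)=O)OC=C(C(=O)OC)[C@H]1CC(=O)OCCCCCCCCCCCCCCC` — 8000 nM
Compound 2 `C/C=C1/[C@H](O[C@@H]2O[C@H](CO)[C@@H](O)[C@H](O)[C@H]2O)OC=C(C(=O)OC)[C@H]1CC(=O)OCCC1CCCCC1` — 480 nM
Compound 3 `C/C=C1/[C@H](O[C@@H]2O[C@H](CO)[C@@H](O)[C@H](O)[C@H]2O)OC=C(C(=O)O)[C@H]1CC(=O)O` — > 50000 nM

All three share a glucoside core carrying an ester side chain, and were tested in a functional assay on HL-60 cells (Homo sapiens) for antiproliferative activity, read by MTT assay, with a stated time of 72 h; on this read-out lower numbers stand for stronger inhibition and higher numbers for weaker inhibition. Compound 2 `C/C=C1/[C@H](O[C@@H]2O[C@H](CO)[C@@H](O)[C@H](O)[C@H]2O)OC=C(C(=O)OC)[C@H]1CC(=O)OCCC1CCCCC1` gives 480 nM, the lowest number of the two plain values; compound 1 `C/C=C1/[C@H](O[C@@H]2O[C@H](COC(C)=O)[C@@H](OC(C)=O)[C@H](OC(C)=O)[C@H]2OC(C)=O)OC=C(C(=O)OC)[C@H]1CC(=O)OCCCCCCCCCCCCCCC`, with an acetylated sugar and a long saturated chain on the ester, gives 8000 nM, a gap beyond the usual scatter. Compound 3 `C/C=C1/[C@H](O[C@@H]2O[C@H](CO)[C@@H](O)[C@H](O)[C@H]2O)OC=C(C(=O)O)[C@H]1CC(=O)O`, which carries two free carboxylic acids instead of esters, shows only a limit of the assay, > 50000 nM, the same limit noted as the limit of > 50000 nM in this assay, at which 1 of the 3 values shown sits.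

The next compound, compound 4 `C/C=C1/[C@H](O[C@@H]2O[C@H](CO)[C@@H](O)[C@H](O)[C@H]2O)OC=C(C(=O)OC)[C@H]1CC(=O)OCCc1ccc(O)c(O)c1`, keeps the free sugar and the methyl ester of compound 2 and changes only the ester side chain: 3,4-dihydroxyphenyl in place of cyclohexyl on a saturated chain carbon, two bonds along the chain from an oxygen next to a carbonyl group. Within the data shown here, no pair of measured compounds differs in one place, so no measured step guides this change. Among the compounds here, the lower numbers belong to the more lipophilic esters, compound 2 above all, while the free acids of compound 3 reach only the limit. Compound 4 is therefore expected to give a higher number, an estimated step of a 31-fold higher number from compound 2 to compound 4 (1.49 log units; beyond the scatter). For compound 4 the estimate is 15000 nM, with a likely range from 3000 nM to 60000 nM.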

Compound 4, half-maximal inhibitory concentration: 54300 nM
Estimate against measurement, compound 4: 3.6-fold (0.56 log units) below, within the range that was stated.
By their numbers in this assay, from the lowest: compound 2; then compound 1; then compound 4.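

In this assay, with the free sugar and the methyl ester held fixed, 3,4-dihydroxyphenyl in place of cyclohexyl on a saturated chain carbon, two bonds along the chain from an oxygen next to a carbonyl group, gives a 110-fold higher number from compound 2 to compound 4 (2.05 log units; beyond the scatter). This is the first change in one place among these compounds, and it shows that the read-out is highly sensitive to which six-membered ring ends this side chain. The change swaps a non-aromatic ring with 0 hydrogen-bond donors and 0 acceptors for an aromatic ring with 2 donors and 2 acceptors, and this single comparison cannot show which of these differences carries the step. Compound 3 stays a limit and not a number, so it cannot be ranked against compound 4: the limit of > 50000 nM in this assay, at which 1 of the 4 values shown sits.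

A plain phenyl group at the same place would help separate the part played by the aromatic ring from the part played by its two hydroxyl groups. Also open, on these data alone, is how a longer chain between the ester oxygen and the cyclohexyl ring would affect the number.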